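The compounds below may be only part of what the source reports. "The series", "measured", "known", "first", "only" and "open" are said of these compounds alone.

Compound 1 `O=C(Nc1c(O)cccc1-c1nc2c(C(=O)O)cccc2o1)c1ccccn1` carries a pyridin-2-yl group on its carbonyl carbon. For the measured compounds named here, in an ADME assay on L6 cells (Rattus norvegicus) for cytotoxicity (on this read-out lower numbers stand for stronger inhibition and higher numbers for weaker inhibition), compound 1 gives 30600 nM, the lowest of the two numbers known so far; its nearest neighbour is compound 2 `O=C(Nc1c(O)cccc1-c1nc2c(C(=O)O)cccc2o1)c1ccc(F)c(F)c1F`, which in this assay gives 210000 nM. That gap, a 6.9-fold higher number from compound 1 to compound 2 (0.84 log units; beyond the scatter), comes from a 2,3,4-trifluorophenyl in place of the pyridin-2-yl on the carbonyl carbon. Compound 3 `O=C(Nc1c(O)cccc1-c1nc2c(C(=O)O)cccc2o1)c1ncccc1O` keeps the shared core and differs from compound 1 by hydroxy in place of hydrogen on an aromatic carbon, so that the pyridin-2-yl becomes a 3-hydroxypyridin-2-yl. Going by the values given here, the single measured step exchanges the whole ring rather than adding a hydroxy to it, so it does not bear directly on this change; with no closer precedent, no step beyond the scatter is expected in this assay. Compound 3 is therefore estimated at about 35000 nM, with a range from 10000 nM to 120000 nM. The expected step is a 1.1-fold higher number from compound 1 to compound 3 (0.06 log units; within the scatter).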

Compound 3, half-maximal inhibitory concentration: 14200 nM
Compound 3: the middle estimate sits 2.5-fold (0.39 log units) above what was measured; the range from low to high includes it.
By their numbers in this assay, from the lowest: compound 3; then compound 1; then compound 2.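

Hydroxy in place of hydrogen on this aromatic carbon, ortho to a large group and two atoms from the ring nitrogen, is not a silent change in this assay: it gives a 2.2-fold lower number from compound 1 to compound 3 (0.33 log units; beyond the scatter) and so moves the number in the opposite direction from the earlier ring exchange. The exchange of the whole ring on the carbonyl carbon now also spans a wider range, with a 15-fold lower number from compound 2 to compound 3 (1.17 log units; beyond the scatter). Compound 3 therefore has the lowest number of the three, and its steps to both others lie beyond the scatter. Nothing available explains why the number falls. The compounds shown leave open whether a methoxy group or an amine at this same position would lower the number as hydroxy does. They also leave open whether the hydroxy would do the same on another carbon of the ring.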